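The source may hold more compounds than are shown below. What is called first, only, known or untested is meant among the compounds shown, and "the series" means these compounds.

Compound 1 `O=C(O)[C@@H]1NC[C@@H](O)[C@@H](O)[C@H]1O` gives 26% in an assay on isolated protein for inhibition of cytosolic endo-beta-N-acetylglucosaminidase (Homo sapiens), tested at 1000 uM; on this read-out lower numbers stand for less inhibition and higher numbers for more inhibition at the one concentration tested (going by the name of the read-out). Among the compounds with values here, compound 2 `O=C(O)[C@H]1NC[C@H](O)[C@@H](O)[C@H]1O` gives 2.6% in this assay, the lower of the two numbers measured so far. Within the data shown here, the only measured step is a number 23.4 percentage points lower from compound 1 to compound 2 (beyond the scatter), a change that rests on (the fact that compounds 1 and 2 differ only in the configuration as drawn). Compound 3 `O=C(O)[C@@H]1NC[C@H](O)[C@H](O)[C@H]1O` differs from compound 2 as follows: the two compounds have the same atoms and bonds and differ only in configuration as drawn: 2 of 4 stereo elements differ; a stereocentre at a saturated ring carbon is drawn S in compound 2 and R in compound 3; a stereocentre at a saturated ring carbon is drawn R in compound 2 and S in compound 3. A swap of two ring configurations moved this assay modestly once; a rise from the low number of compound 2 is plausible but unsupported by more data. Compound 3 is therefore estimated at 12%, within 0% to 35%, an expected step of a number 9.4 percentage points higher from compound 2 to compound 3 (within the scatter).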

Compound 3, a percentage reported as inhibition, at one concentration (the size of the read-out at that concentration, not a potency): 39%
Estimate against measurement, compound 3: 27 percentage points below, and the stated range ends below it.
By their numbers in this assay, from the lowest: compound 2; then compound 1; then compound 3.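

Ring configuration alone can move the number in either direction in this assay: the series now holds a number 36.4 percentage points higher from compound 2 to compound 3 (beyond the scatter), and also a number 13 percentage points higher from compound 1 to compound 3 (beyond the scatter). Compound 3 stands highest of the three, with both of its steps beyond the scatter. No atom or bond changes along the larger step: the fact that compounds 2 and 3 differ only in the configuration as drawn

On these data alone, each pair differs at two stereocentres at once, so the contribution of each single centre remains open. Also open, as far as these compounds go, is how a hydroxymethyl group in place of the carboxylic acid would read on the configuration of compound 3.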